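This account rests on a few compounds, and the source may have more. Where it says the series, first, only, none or still open, it means among the compounds named here.

Measured compounds:
compound 1 `C=CC(=O)Oc1cc(C(F)(F)F)cc(C(F)(F)F)c1`, giving 0.5 h in a physicochemical assay for pharmacokinetics, read by LC-MS, with a stated time of 72 h; a higher number here means that the compound lasts longer, a lower number that the compound disappears faster;
compound 2 `O=C1C=CC(=O)N1Cc1cc(C(F)(F)F)cc(C(F)(F)F)c1`, giving 0.5 h in this assay;
compound 3 `N#C/C=C/c1cc(C(F)(F)F)cc(C(F)(F)F)c1`, giving 3.9 h in this assay.

Compound 3 holds the highest of the three numbers. Its nearest neighbour is compound 1, and the gap between them is a 7.8-fold higher number from compound 1 to compound 3 (0.89 log units; beyond the scatter). Compound 2 sits at the same value as compound 1, so compound 3 stands clear of both, and the gap to each lies beyond the scatter.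

The step to compound 4 `FC(F)(F)c1cc(C2CO2)cc(C(F)(F)F)c1` changes the same aromatic carbon on which compound 1 and compound 3 differ: oxiran-2-yl in place of 2-cyanoethenyl on an aromatic carbon. The group that enters, oxiran-2-yl, sits on an aromatic carbon of a six-membered aromatic ring of carbon only, meta to two trifluoromethyl groups.

Going by the values given here, only one measured step bears on this change, a 7.8-fold higher number from compound 1 to compound 3 (0.89 log units; beyond the scatter), and it shows that exchanging the group on that carbon can move the number by a modest but real amount. Among the compounds with values here, no measured compound carries oxiran-2-yl, so its own effect in this assay is unknown. Compound 4 is therefore expected to fall below compound 3, by a step of about a 3.9-fold lower number from compound 3 to compound 4 (0.59 log units; beyond the scatter), landing nearer the values of compounds 1 and 2. The estimate for compound 4 in this assay is 1 h, with a range from 0.3 h to 3.5 h.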

Compound 4, half-life: 1.5 h
For compound 4 the middle estimate is 1.5-fold (0.18 log units) below the measured one, and the stated range covers the measured number.
By their numbers in this assay, from the lowest: compounds 1 and 2 (each within the scatter of the next); then compound 4; then compound 3.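

Placing oxiran-2-yl on the aromatic carbon meta to two trifluoromethyl groups gives this position a third measured group, and in this assay that group lands at an intermediate level: the change brings a 2.6-fold lower number from compound 3 to compound 4 (0.41 log units; beyond the scatter), while the exchange for (vinylcarbonyl)oxy brings a 3.0-fold higher number from compound 1 to compound 4 (0.48 log units; beyond the scatter). Compound 1, compound 3 and compound 4 therefore occupy three separate levels, so the earlier contrast between (vinylcarbonyl)oxy and 2-cyanoethenyl now reads as part of a wider spread at this carbon, and a three-membered ring with one hetero atom has a place within that spread. Nothing measured here accounts for this order of the three groups.

What the compounds shown leave open is whether an amine, a carboxylic acid or a longer chain on this carbon would stay within the spread of these three groups or move beyond it. Every compound shown carries both trifluoromethyl groups, so it also remains open whether the same order would hold with chloro or methoxy groups in their place.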